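From a Limit Toward a Small Methoxyamide

The source may hold more compounds than are shown below. What is called first, only, known or untested is meant among the compounds shown, and "the series" means these compounds.

Compound 3 `CC(C)=CCCC1=CC[C@H](C(=O)Nc2ccc(C(=O)O)cc2)[C@@H](c2ccccc2)C1` stands at the weak end of the set: in an assay on isolated protein for inhibition of Apoptosis regulator Bcl-2 (Homo sapiens), read by fluorescence polarization, with stated times of 5 min and 10 min (on this read-out higher numbers stand for weaker inhibition and lower numbers for stronger inhibition), compound 3 gives > 23000 nM, which is a limit of the assay rather than a number. Its mirror image, compound 2 `CC(C)=CCCC1=CC[C@@H](C(=O)Nc2ccc(C(=O)O)cc2)[C@H](c2ccccc2)C1`, gives 2200 nM, and an at least 10-fold higher number from compound 2 to compound 3 (1.01 log units; beyond the scatter). Compound 1 `COC(=O)CCNC(=O)[C@H]1CC=C(CCC=C(C)C)C[C@@H]1c1ccccc1` shares the configuration of compound 3, and in this assay compound 1 gives 3100 nM. The step to compound 4 `CONC(=O)[C@H]1CC=C(CCC=C(C)C)C[C@@H]1c1ccccc1` is methoxy in place of 4-carboxyphenyl on an amide-type nitrogen. It runs opposite to an at least 7.4-fold higher number from compound 1 to compound 3 (0.87 log units; beyond the scatter), where the small substituent on the amide nitrogen carried the lower number. A step of comparable size back toward the range of compound 1 is therefore expected, so compound 4 is expected to show an at least 3.8-fold lower number from compound 3 to compound 4 (0.58 log units; beyond the scatter). The estimate for compound 4 is 6000 nM, within 1500 nM to 25000 nM.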

Compound 4, inhibition constant: 2400 nM
Beside the measured number, compound 4's estimate is 2.5-fold (0.40 log units) above it; the range from low to high includes it.
By their numbers in this assay, from the lowest: compounds 2, 4 and 1 (each within the scatter of the next). At a limit, above all of these: compound 3.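

Methoxy in place of 4-carboxyphenyl on the amide-type nitrogen gives an at least 9.5-fold lower number from compound 3 to compound 4 (0.98 log units; beyond the scatter), so within this configuration the substituent on that nitrogen alone can carry a compound away from the limit. That limit belongs to compound 3 and is not a number: the limit of > 23000 nM in this assay, at which 1 of the 4 values shown sits.

Methoxy in place of 2-(methoxycarbonyl)ethyl gives a 1.3-fold lower number from compound 1 to compound 4 (0.11 log units; within the scatter), so these two different substituents cannot be told apart in this assay, and the ester chain is not needed to hold that level.

Left open is whether a hydroxyl or a plain methyl on this nitrogen reads the same. Also open, on these data alone, is how methoxy reads on the mirror-image configuration of compound 2.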